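Swapping the aryl group on the saturated ring carbon

The compounds below may be only part of what the source reports. "The series", "measured", "known", "first", "only" and "open" are said of these compounds alone.

Compound 3 `COc1ccc(C2OC(c3cc(OC)c(OC)c(OC)c3)=NN2C(C)=O)c(OC)c1` is one of three compounds tested in a functional assay on BGC-823 cells (Homo sapiens) for antiproliferative activity, read by MTT assay, tested at 1 uM; on this read-out lower numbers stand for a weaker effect and higher numbers for a stronger effect at the one concentration tested. In this assay compound 3 gives 6.3%. Compound 1 `COc1cc(C2=NN(C(C)=O)C(c3cccc(F)c3)O2)cc(OC)c1OC` gives 14.7% in this assay, and compound 2 `COc1ccc(OC)c(/C=N/NC(=O)c2cc(OC)c(OC)c(OC)c2)c1` gives 0.1%. Compound 3 therefore holds the second highest of the three numbers, but each gap among these three sits within the usual scatter of such measurements, so none of them can be told apart. Compound 4 `COc1cc(C2=NN(C(C)=O)C(c3ccccc3C(F)(F)F)O2)cc(OC)c1OC` has not yet been measured. It differs from compound 3 in one place: 2-(trifluoromethyl)phenyl in place of 2,4-dimethoxyphenyl on a saturated ring carbon. Going by the values given here, one measured step touches this same place, namely a number 8.4 percentage points lower from compound 1 to compound 3 (within the scatter); there, too, one aryl group replaced another on the saturated ring carbon, and the read-out did not move beyond the scatter. On that basis the new aryl group in compound 4 is expected to leave this assay's read-out about where compound 3 stands, with a step of a number 2.7 percentage points higher from compound 3 to compound 4 (within the scatter) that stays within the scatter. The estimate for compound 4 is 9%, with a likely range from 0% to 22%.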

Compound 4, a percentage reported as inhibition, at one concentration (the size of the read-out at that concentration, not a potency): 31.8%
Beside the measured number, compound 4's estimate is 22.8 percentage points below it; the measured number lies above the stated range.
By their numbers in this assay, from the lowest: compounds 2, 3 and 1 (each within the scatter of the next, the first and the last beyond it); then compound 4.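

At this saturated ring carbon, the choice of aryl group can move the read-out in this assay: 2-(trifluoromethyl)phenyl gives a number 25.5 percentage points higher from compound 3 to compound 4 (beyond the scatter) and a number 17.1 percentage points higher from compound 1 to compound 4 (beyond the scatter). Going by these compounds alone, the one earlier step at this carbon stayed within the scatter, whereas both of these steps lie beyond it, the first evidence that this position responds to a change of group. Nothing measured here accounts for the rise.

Still open, on these data alone, is whether the trifluoromethyl group itself matters or the whole 2-(trifluoromethyl)phenyl group is needed, and how a different group on this carbon, such as a simple amine or a longer alkyl chain, would fare. These numbers also come from a single concentration, which shows the size of the effect there but not a potency.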